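This account rests on a few compounds, and the source may have more. Where it says the series, first, only, none or still open, it means among the compounds named here.

Measured compounds: compound 1 `CC(C)c1ccc2c(Nc3cc(C(=O)N[C@@H](C)c4ccccc4)ccc3Sc3ccc(N)cc3)ncnc2n1` gives 1.6 h in an ADME assay on the whole organism (strain Sprague-Dawley) for metabolic stability, with Rattus norvegicus as the target, at a dose of 5 mg/kg by the intravenous route; a higher number here means that the compound lasts longer, a lower number that the compound disappears faster; compound 2 `Cc1ccc([C@H](C)NC(=O)c2ccc(Sc3ccc(N)cc3)c(Nc3ncnc4nc(C(C)C)ccc34)c2)cc1` gives 0.7 h in this assay.

Compound 2 stands at the lower of the two numbers; its nearest neighbour is compound 1, and the difference between them is a 2.3-fold lower number from compound 1 to compound 2 (0.36 log units; beyond the scatter), which arose from a methyl in place of hydrogen on an aromatic carbon.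

Compound 3 `CC(C)c1ccc2c(Nc3cc(C(=O)N[C@@H](C)C4CCCCC4)ccc3Sc3ccc(N)cc3)ncnc2n1` has not yet been measured. It differs from compound 2 as follows: cyclohexyl in place of 4-methylphenyl on a saturated chain carbon bound to an amide-type nitrogen and a saturated chain carbon. Among the compounds with values here, no measured step covers this kind of exchange, so only the one step from compound 1 to compound 2 offers a hint, and that step concerned a different change. The methyl that lowered the number is gone in compound 3, yet the whole aromatic ring is exchanged too, so the outcome is open.

Compound 3 is therefore expected to land near 1 h, within 0.4 h to 2.5 h, which means an expected step of a 1.4-fold higher number from compound 2 to compound 3 (0.15 log units; within the scatter).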

Compound 3, half-life: 0.5 h
The estimate for compound 3 lay 2.0-fold (0.30 log units) above the measured number, and the stated range covers the measured number.
By their numbers in this assay, from the lowest: compounds 3 and 2 (each within the scatter of the next); then compound 1.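

In this assay the exchange of phenyl for cyclohexyl gives a 3.2-fold lower number from compound 1 to compound 3 (0.51 log units; beyond the scatter) and so shows that, on the saturated chain carbon bound to an amide-type nitrogen and a saturated chain carbon, this non-aromatic ring does not keep the number seen with plain phenyl. Cyclohexyl in place of 4-methylphenyl gives a 1.4-fold lower number from compound 2 to compound 3 (0.15 log units; within the scatter) and so leaves these two groups indistinguishable here, with both set apart from phenyl on the low side. Nothing available explains why these groups give these numbers.

On these data alone, whether cyclopentyl, or a cyclohexyl ring carrying an amine or a hydroxyl group, would fall with phenyl or with cyclohexyl remains open. Also open, as far as these compounds go, is how a fluorine in place of the methyl of 4-methylphenyl would compare with either group.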